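Swapping the Methylsulfonylphenyl Group for Pyridinyl

This account rests on a few compounds, and the source may have more. Where it says the series, first, only, none or still open, it means among the compounds named here.

Compound 1 `CS(=O)(=O)c1ccc(-c2cnc3[nH]cc(-c4nnc(-c5ccncc5)o4)c(=O)c3c2)cc1` in a functional assay on HCT-116 cells (Homo sapiens) for inhibition, read by MTT assay, with a stated time of 24 h, tested at 5 uM (on this read-out lower numbers stand for less inhibition of growth and higher numbers for more inhibition of growth at the one concentration tested), gives 5.61%.
Compound 2 `CS(=O)(=O)c1ccc(-c2cnc3[nH]cc(-c4nnc(-c5ccc(F)cc5)o4)c(=O)c3c2)cc1` in this assay gives 14.9%.

Compound 2 and compound 1 sit within the scatter of each other, as the step of a number 9.3 percentage points higher from compound 1 to compound 2 (within the scatter) shows, so neither stands apart. Compound 3 `O=c1c(-c2nnc(-c3ccc(F)cc3)o2)c[nH]c2ncc(-c3ccncc3)cc12` differs from compound 2 at a different site: pyridin-4-yl in place of 4-(methylsulfonyl)phenyl on an aromatic carbon. Among the measured compounds shown here, no measured pair changes that group, and the one known step, a number 9.3 percentage points higher from compound 1 to compound 2 (within the scatter), concerns another position, so it offers no direct guide. With nothing bearing on the change, no shift beyond the scatter is expected in this assay. Compound 3 is therefore estimated at 11%, between 0% and 28%, an expected step of a number 3.9 percentage points lower from compound 2 to compound 3 (within the scatter).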

Compound 3, percent growth inhibition at one concentration: 10.9%
Estimate against measurement, compound 3: 0.1 percentage points above, and the stated range covers the measured number.
By their numbers in this assay, from the lowest: compounds 1, 3 and 2 (each within the scatter of the next).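

Moving to this second position, this assay shows a number 4 percentage points lower from compound 2 to compound 3 (within the scatter) when pyridin-4-yl takes the place of 4-(methylsulfonyl)phenyl on the shared core. Among the compounds shown here, compounds 1 and 2 varied only the other end of the molecule, so this is the first sign that this position also tolerates a swap of aromatic rings without leaving the scatter. No measurement at hand bears on why the two groups read alike.

On these data alone, whether a non-aromatic group here, such as an amine or a carboxylic acid, would move the number beyond the scatter remains open.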